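Changing the side chain of a lipid-like aminosugar

A few compounds are considered here, and "the series" means these few. Any claim that something is new, unique, unknown or untested is made for them only; others in the source may bear on it.

Compound 1, with the structure `CCCCCCCCCO[C@@H]1[C@@H](N)[C@@H](OCC(O)CNCCCO)O[C@H](CN)[C@H]1OCCCCCCCCC`, carries two long nonyl chains on its sugar core and a side chain ending in a (3-hydroxypropyl)amino group. In a toxicity assay on the whole organism (J774 cells) for cytotoxicity, with Mus musculus as the target, read by MTT assay, with a stated time of 24 h, tested at 30 uM (a lower number here means a stronger effect, a higher number a weaker effect of the compound at the concentration tested), compound 1 gives 13.7%, the lowest of the three numbers and therefore the strongest effect on the cells. Compound 3, with the structure `C=CCO[C@H]1O[C@H](CN)[C@@H](OCc2ccc3ccccc3c2)[C@H](OCc2ccc3ccccc3c2)[C@H]1N`, gives 28.3% in this assay, and compound 2, with the structure `NC[C@H]1O[C@H](O[C@H]2[C@H](O)[C@@H](O)[C@H](N)C[C@@H]2N)[C@H](N)[C@@H](OCCCc2ccc3ccccc3c2)[C@@H]1OCCCc1ccc2ccccc2c1`, gives 66.9%; both steps away from compound 1 lie beyond the usual scatter.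

Compound 4, with the structure `CCCCCCCCCO[C@@H]1[C@@H](N)[C@@H](OCC(O)CO)O[C@H](CN)[C@H]1OCCCCCCCCC`, keeps everything else of compound 1 and differs only at the end of the side chain: hydroxy in place of (3-hydroxypropyl)amino on a saturated chain carbon, two bonds along the chain from an oxygen on a saturated carbon. Among the measured compounds shown here, no measured pair shows this exact change, so its effect is not known from the data. Given that compound 1 gives 13.7%, the expectation is that compound 4 acts somewhat more weakly, with a step of a number 16.3 percentage points higher from compound 1 to compound 4 (beyond the scatter) estimated to go upward beyond the scatter. Compound 4 is expected to give about 30%, within a range from 12% to 55%.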

Compound 4, a percentage reported as activity, at one concentration (the size of the read-out at that concentration, not a potency): 8.8%
Estimate against measurement, compound 4: 21.2 percentage points above; measured number outside the range, below it.
By their numbers in this assay, from the lowest: compounds 4 and 1 (each within the scatter of the next); then compound 3; then compound 2.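

Replacing the (3-hydroxypropyl)amino end of the side chain with hydroxy gives a number 4.9 percentage points lower from compound 1 to compound 4 (within the scatter) in this assay, so the two compounds cannot be told apart in this assay. At this concentration, the strong effect on the cells therefore does not require the (3-hydroxypropyl)amino group, and the 2,3-dihydroxypropyl side chain of compound 4 serves as well. Nothing available here gives a cause for this result.

From the compounds shown here alone, it remains open whether a carboxylic acid or a longer chain at the same place would shift the number, and whether compound 1 and compound 4 would separate at a lower concentration. Going by these compounds, the role of the two nonyl chains also stays open, since compound 2 and compound 3 differ from compound 1 in more than one place.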